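Lengthening the chain once more on a rice growth read-out

A few compounds are considered here, and "the series" means these few. Any claim that something is new, unique, unknown or untested is made for them only; others in the source may bear on it.

For the measured compounds named here, the two compounds measured so far share one core and differ only in the chain on the aromatic ring. Compound 1 `CCCCc1ccc(NC(=O)N[C@@H](C)c2ccccc2)cc1` carries a butyl chain, and in an ADME assay on the whole organism with Oryza sativa as the target, tested at 10 uM (on this read-out lower numbers stand for a stronger effect and higher numbers for a weaker effect at the one concentration tested), compound 1 gives 60%. Compound 2 `CCCCCCc1ccc(NC(=O)N[C@@H](C)c2ccccc2)cc1` carries a hexyl chain, and in this assay compound 2 gives 99%, the higher of the two numbers and so the weaker effect. Going by the values given here, the only step available, a number 39 percentage points higher from compound 1 to compound 2 (beyond the scatter), shows that adding carbon to this chain moved the read-out sharply towards a weaker effect. Compound 3 `CCCCCCCc1ccc(NC(=O)N[C@@H](C)c2ccccc2)cc1` extends the same chain again: methyl in place of hydrogen on a saturated chain carbon, six bonds along the chain from an aromatic carbon. Since compound 2 already sits near the top of the read-out with 99%, there is little room to move further in that direction, so a step of a number 1 percentage points lower from compound 2 to compound 3 (within the scatter) is expected, which is none beyond the scatter. Compound 3 is therefore estimated to give 98%, within 85% to 105%.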

Compound 3, a percentage reported as activity, at one concentration (the size of the read-out at that concentration, not a potency): 99%
For compound 3 the middle estimate is 1 percentage points below the measured one; measured number inside the range.
By their numbers in this assay, from the lowest: compound 1; then compounds 2 and 3 (each within the scatter of the next).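

In this assay, the methyl at this place, six bonds along the chain from an aromatic carbon, gives no change at the digits printed from compound 2 to compound 3 (within the scatter), so here a further carbon on the chain has no effect that can be told from the scatter, unlike the earlier lengthening. Measured against the butyl chain of compound 1, the chain of compound 3 gives a number 39 percentage points higher from compound 1 to compound 3 (beyond the scatter), so the large difference from the butyl chain is kept and this further methyl does not reverse it. No measurement available here gives a reason for this result.

The compounds shown leave open whether a longer chain would stay at the same number or move away from it. They also leave open how a chain carrying an amine or a carboxylic acid would read in this assay.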